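Two Fluorines in Place of a Methyl on the Aryl Ring

The source may report more compounds than this note shows. Statements on the series, on what has been measured and on what is new or still open speak of the compounds shown alone.

Within the data shown here, compound 2 `CCCCCCC(Sc1nc(Cl)cc(Nc2nc(-c3ccc(C)cc3)cs2)n1)C(=O)O` holds the only measured number here: in an assay for inhibition of Polyunsaturated fatty acid 5-lipoxygenase (Homo sapiens), read by HPLC, with stated times of 15 min and 10 min (a higher number here means a weaker inhibitor, a lower number a stronger inhibitor), compound 2 gives 200 nM. Compound 1 `O=C(O)CSc1nc(Cl)cc(Nc2nc(-c3ccc(Cl)cc3)cs2)n1` gives only a limit of this assay, > 10000 nM (the limit of > 10000 nM in this assay, at which 1 of the 2 values shown sits). Compound 3 `CCCCCCC(Sc1nc(Cl)cc(Nc2nc(-c3ccc(F)cc3F)cs2)n1)C(=O)O` differs from compound 2 in one place, (2,4-difluorophenyl in place of 4-methylphenyl on an aromatic carbon). Among the measured compounds shown here, no two measured compounds differ in a single place, so no earlier step guides this one; the step from compound 2 to compound 3 is expected to be a 1.5-fold higher number from compound 2 to compound 3 (0.18 log units; within the scatter), not beyond the usual scatter. Compound 3 is therefore estimated at 300 nM, with a range from 120 nM to 900 nM.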

Compound 3, half-maximal inhibitory concentration: 1500 nM
Beside the measured number, compound 3's estimate is 5.0-fold (0.70 log units) below it; the measured number lies above the stated range.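

In this assay, the group on this aromatic carbon proves to matter: 2,4-difluorophenyl in place of 4-methylphenyl gives a 7.5-fold higher number from compound 2 to compound 3 (0.88 log units; beyond the scatter). Even a swap between two phenyl groups, neither with a hydrogen-bond donor or acceptor, weakens inhibition here. Nothing shown gives a measured reason for this step.

Still open, on these data alone, is how a 4-fluorophenyl or a 4-methoxyphenyl group would compare on this carbon. Such groups could show whether a single fluorine or the loss of the methyl goes with the higher number.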